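Indole for 4-methylphenyl: working notes on solubility

This account rests on a few compounds, and the source may have more. Where it says the series, first, only, none or still open, it means among the compounds named here.

Measured in a physicochemical assay for solubility; on this read-out higher numbers stand for higher solubility and lower numbers for lower solubility
- Compound 1 `CNC(=O)c1cc(C(=O)NC2CC2)cn(Cc2ccc(C)cc2)c1=O` gives 24 ug/mL
- Compound 2 `CNC(=O)c1cc(C(=O)NC2CC2)cn([C@H](C)c2ccccc2)c1=O` gives >= 168 ug/mL (a limit)

Among the measured compounds shown here, compound 1 holds the only exact number in this assay so far, so its place can be read only against a limit. The change to compound 3 `CNC(=O)c1cc(C(=O)NC2CC2)cn(Cc2cccc3[nH]ccc23)c1=O` is 1H-indol-4-yl in place of 4-methylphenyl on a saturated chain carbon bound to an aromatic nitrogen, which brings in a five-membered aromatic ring with 1 hetero atom and 1 hydrogen-bond donor. For the measured compounds named here, one measured step bears on this, and only loosely: an at least 7.0-fold higher number from compound 1 to compound 2 (0.84 log units; beyond the scatter). For compound 2 the end of that step is the limit of >= 168 ug/mL in this assay, at which 1 of the 2 values shown sits. Going by the values given here, that exchange differs from the one in compound 3, so the direction stays open and no step beyond the scatter is expected in this assay. The expected step is a 1.0-fold higher number from compound 1 to compound 3 (0.02 log units; within the scatter). Compound 3 is expected at 25 ug/mL, with an estimated range of 8 ug/mL to 80 ug/mL.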

Compound 3, solubility: 78 ug/mL
Compound 3: the middle estimate sits 3.1-fold (0.49 log units) below what was measured; the measured number falls inside the stated range.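

In this assay, exchanging 4-methylphenyl for 1H-indol-4-yl on the saturated chain carbon bound to an aromatic nitrogen gives a 3.3-fold higher number from compound 1 to compound 3 (0.51 log units; beyond the scatter). Both ends of this step are exact numbers, so its size can be read directly, which the earlier step ending at a limit did not allow. The shared core and the saturated chain carbon stay the same, showing that an exchange of the aromatic group alone can carry the number beyond the scatter.

The entering group adds a second ring, a ring nitrogen and a hydrogen-bond donor together, and a naphthyl group or a 1-methylindol-4-yl group would be needed to pull these apart. Compound 2 remains a limit and not a number: the limit of >= 168 ug/mL in this assay, at which 1 of the 3 values shown sits.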